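A few compounds are considered here, and "the series" means these few. Any claim that something is new, unique, unknown or untested is made for them only; others in the source may bear on it.

Compound 1 `Cc1cc(C)n(-c2nc(-c3cccnc3)cc(=O)[nH]2)n1`: in an ADME assay on CHO cells (Cricetulus griseus) for cytotoxicity, read by MTT assay (a higher number here means a weaker inhibitor, a lower number a stronger inhibitor), compound 1 reaches only the limit of the assay, > 50000 nM.
Compound 2 `Cc1cc(-c2ccccc2)n(-c2nc(C(F)(F)F)cc(=O)[nH]2)n1`: in this assay compound 2 also stops at the limit of the assay, > 50000 nM.
Compound 3 `CCNc1cc(C)nn1-c1nc(C(F)(F)F)cc(=O)[nH]1`: in this assay compound 3 gives 8000 nM.

Among the measured compounds shown here, compound 3 is therefore the only compound of the three with an actual number; the other two sit at the limit of > 50000 nM in this assay, at which 2 of the 3 values shown sit, so their numbers can only be said to be larger than that limit. For the measured compounds named here, the one measured step that leads to compound 3 is an at least 6.2-fold lower number from compound 2 to compound 3 (0.79 log units; beyond the scatter), which moves from a limit to a number, so its true size is not fully known.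

Compound 4 `Cc1cc(NC2CCOCC2)n(-c2nc(C(F)(F)F)cc(=O)[nH]2)n1` differs from compound 3 by oxan-4-yl in place of ethyl on a nitrogen on an aromatic ring. Going by the values given here, no measured step touches the ethylamino group itself, so the only guide is that compound 3 carries an alkylamino group and is the one measured compound with a number. A change of the alkyl group alone is expected to leave the value near that of compound 3, with a 1.3-fold higher number from compound 3 to compound 4 (0.10 log units; within the scatter) expected to stay within the usual scatter. Compound 4 is therefore estimated at 10000 nM in this assay, with a range from 3500 nM to 35000 nM.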

Compound 4, half-maximal inhibitory concentration: 18000 nM
Compound 4: the middle estimate sits 1.8-fold (0.26 log units) below what was measured, within the range that was stated.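

In this assay, among the compounds shown here, the group carried on this nitrogen is not a silent passenger: oxan-4-yl in place of ethyl gives a 2.3-fold higher number from compound 3 to compound 4 (0.35 log units; beyond the scatter), a modest step, and the earlier compounds offered no comparison of two groups at this place. The alkyl part of the amino group can therefore move the number, and in this one pair the six-membered ring with its oxygen goes with the higher number, meaning a weaker inhibitor. Compound 4 also keeps a measured number where the phenyl compound has none, with (oxan-4-yl)amino in place of phenyl giving an at least 2.7-fold lower number from compound 2 to compound 4 (0.44 log units; beyond the scatter), and the true size of that step stays unknown because compound 2 stands at a limit: the limit of > 50000 nM in this assay, at which 2 of the 4 values shown sit.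

With only ethyl and oxan-4-yl to compare, the ring and its oxygen cannot be told apart as the source of the change, and a cyclohexyl group, which has the ring without the oxygen, would separate the two. Also open, on these data alone, is how a longer chain such as n-butyl, or a plain amino group with no alkyl group on the nitrogen, would compare with compound 3.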